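One Sugar Carrier, Four Different Attached Groups

The compounds below may be only part of what the source reports. "The series", "measured", "known", "first", "only" and "open" are said of these compounds alone.

Compound 1, `CC1=CC[C@@H](C(C)(C)O[C@@H]2O[C@H](COC(=O)c3cc(O)c(O)c(O)c3)[C@@H](O)[C@H](O)[C@H]2O)CC1`, gives 26.2% in a functional assay, read by spectrophotometry, with a stated time of 30 min, tested at 5 uM; on this read-out lower numbers stand for a weaker effect and higher numbers for a stronger effect at the one concentration tested.
Compound 2, `CC1=CC[C@H](C(C)(C)O[C@@H]2O[C@H](COC(=O)c3cc(O)c(O)c(O)c3)[C@@H](O)[C@H](O)[C@H]2O)CC1`, gives 24.5%.
Compound 3, `C=CCc1cc(OC)c(O)c(O[C@@H]2O[C@H](COC(=O)c3cc(O)c(O)c(O)c3)[C@@H](O)[C@H](O)[C@H]2O)c1`, gives 26.8%.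

Compound 2 holds the lowest of the three numbers, yet its gaps to compound 1 and to compound 3 both lie within the scatter of repeated runs, so no ranking among the three can be read from them. Among the compounds with values here, the only measured step, a number 1.7 percentage points lower from compound 1 to compound 2 (within the scatter), rests on the fact that compounds 1 and 2 differ only in the configuration as drawn and is itself within the scatter. Compound 4, `C=CCc1ccc(O[C@@H]2O[C@H](COC(=O)c3cc(O)c(O)c(O)c3)[C@@H](O)[C@H](O)[C@H]2O)c(OC)c1`, differs from compound 2 by 4-allyl-2-methoxyphenyl in place of 1-methyl-1-(4-methylcyclohex-3-en-1-yl)ethyl on an oxygen on a saturated carbon. Within the data shown here, no measured step covers such an exchange; the configuration step from compound 1 to compound 2 does not touch it. Compound 3 already carries a 4-allyl-2-methoxyphenyl group on the same sugar carrier and its number sits alongside the others. The expected step is therefore about a number 1.5 percentage points higher from compound 2 to compound 4 (within the scatter), nothing beyond the scatter. Compound 4 is estimated at 26%, within 15% to 37%.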

Compound 4, a percentage reported as activity, at one concentration (the size of the read-out at that concentration, not a potency): 31.7%
Compound 4: the middle estimate sits 5.7 percentage points below what was measured; measured number inside the range.
By their numbers in this assay, from the lowest: compounds 2, 1, 3 and 4 (each within the scatter of the next).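

In this assay, putting 4-allyl-2-methoxyphenyl in place of 1-methyl-1-(4-methylcyclohex-3-en-1-yl)ethyl on an oxygen on a saturated carbon reads as a number 7.2 percentage points higher from compound 2 to compound 4 (within the scatter), and equally as a number 5.5 percentage points higher from compound 1 to compound 4 (within the scatter). This exchange swaps a non-aromatic carbon ring for an aromatic ring and brings in a hydrogen-bond acceptor, yet at this position neither step leaves the scatter, so the change in the attached group shows no clear effect on the number. The two steps can be set side by side as two readings of one exchange: the fact that compounds 1 and 2 differ only in the configuration as drawn

None of the attached groups shown carries an amine or a carboxylic acid, and whether either would move the number beyond the scatter stays open. On these data alone, with one concentration tested, these numbers tell only the size of the effect at that concentration, and how the compounds compare at any other concentration stays open.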